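The source may hold more compounds than are shown below. What is called first, only, known or untested is meant among the compounds shown, and "the series" means these compounds.

Compound 1 `Cc1c[se]c(NNC(=O)c2ccccc2)n1` was examined in a functional assay on DU-145 cells (Homo sapiens) for cytotoxicity, read by XTT assay, with a stated time of 72 h; on this read-out lower numbers stand for stronger inhibition and higher numbers for weaker inhibition. In this assay compound 1 gives only a limit, > 89200 nM. Compound 2 `Cc1c[se]c(NNC(=O)c2ccc(Cl)cc2)n1` carries chloro in place of hydrogen on an aromatic carbon. In this assay compound 2 likewise gives only a limit, > 79400 nM. The step that the two limits leave unreadable from compound 1 to compound 2 therefore cannot be read. Compound 3 `CC(=O)N(C(=O)c1ccccc1)N(C(C)=O)c1nc(C)c[se]1` rests on a different core; the difference between the two cores is not broken down here. In this assay compound 3 again gives only a limit, > 68600 nM. Going by the values given here, every value so far thus sits at a limit: the limit of > 89200 nM in this assay, at which 1 of the 3 values shown sits, the limit of > 79400 nM in this assay, at which 1 of the 3 values shown sits, and (the limit of > 68600 nM in this assay, at which 1 of the 3 values shown sits). Compound 4 `CC(=O)N(C(=O)c1ccc(Cl)cc1)N(C(C)=O)c1nc(C)c[se]1`, not yet measured, stands to compound 3 as compound 2 stands to compound 1, with chloro in place of hydrogen on an aromatic carbon, the same change at the same place. The step between compound 1 and compound 2 could not be sized, so the expectation for compound 4 rests on compound 3 giving only the limit > 68600 nM. Compound 4 is therefore expected to give 100000 nM, within an expected range from 40000 nM to 300000 nM. This amounts to an expected step that the limit leaves unreadable from compound 3 to compound 4, most likely reported once more only as a limit.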

Compound 4, half-maximal inhibitory concentration: > 62700 nM
Compound 4 ended at the assay's limit (the forecaster's own chance of this, stated with the estimate: 85%); the middle value does not contradict the limit.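

In this assay compound 4 gives only a limit, > 62700 nM. Compound 3 also gives only a limit, so the step between compound 3 and compound 4 cannot be read, just as the step between compound 1 and compound 2 could not. The compounds shown leave open whether chloro in place of hydrogen on an aromatic carbon changes the read-out on either core.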